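This account rests on a few compounds, and the source may have more. Where it says the series, first, only, none or still open, it means among the compounds named here.

Working notes on the series. Among the compounds with values here, in a functional assay on MCF7 cells (Homo sapiens) for antiproliferative activity, read by MTT assay, with a stated time of 72 h (a higher number here means a weaker inhibitor, a lower number a stronger inhibitor), compound 2 `c1ccc(COc2ccccc2Nc2ncnc3cc4c(cc23)OCCOCCOCCO4)cc1` gives 63300 nM, the higher of the two numerical values so far. Compound 3 `FC(F)(F)c1ccc(COc2ccc(Nc3ncnc4cc5c(cc34)OCCOCCOCCO5)cc2)cc1` gives 28500 nM, a lower number than compound 2, and the gap lies beyond the usual scatter. Compound 1 `c1ccc(COc2ccccc2Nc2ncnc3cc4c(cc23)OCCOCCO4)cc1` gives > 100000 nM, which is a limit and not a number.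

The next step leads to compound 4 `FC(F)(F)c1ccc(COc2ccccc2Nc2ncnc3cc4c(cc23)OCCOCCOCCO4)cc1`, which differs from compound 2 in one place: trifluoromethyl in place of hydrogen on an aromatic carbon. This puts trifluoromethyl in place of hydrogen on an aromatic carbon, para to a large group, so that benzyloxy becomes (4-(trifluoromethyl)benzyl)oxy.

Within the data shown here, no measured pair isolates this change. Among the measured compounds shown here, the only guide is compound 3, at 28500 nM, which carries the same (4-(trifluoromethyl)benzyl)oxy group but also differs from compound 2 elsewhere, so it supports only a weak expectation. In this assay, a small move towards a lower number is expected, possibly no larger than the scatter. The estimated step of a 1.4-fold lower number from compound 2 to compound 4 (0.15 log units; within the scatter) reflects this. A reading reported only as a limit also remains possible. For compound 4, the expected value is 45000 nM, with an estimated range of 18000 nM to 100000 nM.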

Compound 4, half-maximal inhibitory concentration: > 100000 nM
Compound 4 gave a limit, no number; the forecaster's own chance of this, stated with the estimate: 20%; middle value at least 2.2-fold (0.34 log units) from the limit.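

In this assay compound 4 gives > 100000 nM, which is a limit and not a number. For trifluoromethyl in place of hydrogen on an aromatic carbon, para to a large group, the series now has a direct one-place comparison, and it shows no move towards a lower number: the step reads an at least 1.5-fold higher number from compound 2 to compound 4 (0.19 log units; that floor lies within the scatter). Since only a floor is available, the true size of the step stays unknown, and the reading for compound 4 marks the point where this assay stops giving numbers for the series: the limit of > 100000 nM in this assay, at which 2 of the 4 values shown sit.

Still open, going by these compounds, is how far compound 4 lies past the limit, and whether an amine or a carboxylic acid in place of trifluoromethyl at this position of the benzyl group would bring the number below that of compound 2. Also open is whether (4-(trifluoromethyl)benzyl)oxy in place of benzyloxy would go the same way with the group placed as in compound 3, as no pair shown isolates the change there.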